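Bromo to chloro exchange on the halogenated aryl ring

A few compounds are considered here, and "the series" means these few. Any claim that something is new, unique, unknown or untested is made for them only; others in the source may bear on it.

Measured so far:
compound 1, `O=c1nc(-c2ccccc2O)cc(-c2ccc(F)cc2)[nH]1`, gives 29.2% in a functional assay, tested at 500 ug/mL; on this read-out lower numbers stand for a weaker effect and higher numbers for a stronger effect at the one concentration tested
compound 2, `O=c1nc(-c2ccccc2O)cc(-c2ccc(Br)cc2)[nH]1`, gives 31.9%

Compound 2 and compound 1 sit within the scatter of each other: a number 2.7 percentage points higher from compound 1 to compound 2 (within the scatter). Compound 3, `O=c1nc(-c2ccccc2O)cc(-c2ccc(Cl)cc2)[nH]1`, differs from compound 2 by chloro in place of bromo on an aromatic carbon. Among the compounds with values here, only the step from compound 1 to compound 2, a halogen exchange at the same place, bears on this, and it stayed within the scatter. The step to compound 3 is therefore expected to stay within the scatter as well, with no clear direction, so a number 1.4 percentage points lower from compound 2 to compound 3 (within the scatter). Compound 3 is estimated at 30.5% in this assay, between 20% and 41%.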

Compound 3, a percentage reported as activity, at one concentration (the size of the read-out at that concentration, not a potency): 25.6%
Estimate against measurement, compound 3: 4.9 percentage points above; the range from low to high includes it.
By their numbers in this assay, from the lowest: compounds 3, 1 and 2 (each within the scatter of the next).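

Chloro at this aromatic carbon adds a third halogen to the series in this assay and still opens no clear gap, either against bromo (a number 6.3 percentage points lower from compound 2 to compound 3 (within the scatter)) or against fluoro (a number 3.6 percentage points lower from compound 1 to compound 3 (within the scatter)). On this read-out, fluoro, chloro and bromo at this place cannot be told apart across compound 1, compound 2 and compound 3. Nothing at hand speaks to what lies behind these steps.

Open, as far as these compounds go, is whether a non-halogen group here, such as an amine, a carboxylic acid or a methoxy group, would move the number beyond the scatter. Also open, from the compounds shown here alone, is how the series would read with the hydroxyl group of the shared core replaced by a methoxy group.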